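Series notes: methoxy for chloro, compound 2 to compound 4

A few compounds are considered here, and "the series" means these few. Any claim that something is new, unique, unknown or untested is made for them only; others in the source may bear on it.

Measured compounds:
compound 1 `CCc1ccc(-c2cc(Cl)cc(C(=O)Nc3nn[nH]n3)n2)cc1` — 49%
compound 2 `CCCc1ccc(-c2cc(Cl)cc(C(=O)Nc3nn[nH]n3)n2)cc1` — 78%
compound 3 `Nc1ccc(-c2cc(Cl)cc(C(=O)Nc3nn[nH]n3)n2)cc1` — 100%

All three were run in a functional assay on the whole organism with Rattus norvegicus as the target, at a dose of 1 mg/kg by the oral route; a lower number here means a weaker effect, a higher number a stronger effect of the compound at the dose given. Compound 2 stands second of the three numbers: compound 3 sits above it, a number 22 percentage points higher from compound 2 to compound 3 (beyond the scatter), and compound 1 sits below it, a number 29 percentage points higher from compound 1 to compound 2 (beyond the scatter). The remaining step, a number 51 percentage points higher from compound 1 to compound 3 (beyond the scatter), is the largest in the set. All three steps change the ethyl, propyl or amino group on the aromatic carbon; none of them touches the chloro.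

Compound 4 `CCCc1ccc(-c2cc(OC)cc(C(=O)Nc3nn[nH]n3)n2)cc1` has not yet been measured in this assay. It differs from compound 2 in one place: methoxy in place of chloro on an aromatic carbon. Among the measured compounds shown here, this change sits on the six-membered aromatic ring with one nitrogen, meta to the (2H-tetrazol-5-yl)carbamoyl group, a position that no measured step covers. The measured steps at the ethyl, propyl and amino groups were modest to large, but they say nothing about an exchange of chloro for methoxy. The expectation therefore rests on the value of compound 2 alone, with no step beyond the scatter assumed in either direction and a wide range to reflect that. Compound 4 is expected to give 70%, between 35% and 95%. That estimate means a step of a number 8 percentage points lower from compound 2 to compound 4 (within the scatter), expected to stay within the scatter.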

Compound 4, a percentage reported as inhibition, in the whole organism at one dose (the size of the read-out at that dose, not a potency): 73%
For compound 4 the middle estimate is 3 percentage points below the measured one; measured number inside the range.
By their numbers in this assay, from the lowest: compound 1; then compounds 4 and 2 (each within the scatter of the next); then compound 3.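

In this assay, the position opposite the ring nitrogen now has a measured step of its own: methoxy in place of chloro gives a number 5 percentage points lower from compound 2 to compound 4 (within the scatter) and so leaves compound 2 and compound 4 within the scatter of each other. With the propyl group held constant, chloro is therefore not required at this position for an effect of this size at the dose given, and the exchange adds a heavy atom and a hydrogen-bond acceptor without a step beyond the scatter. No measurement shown offers an explanation for this result.

Still open, on these data alone, is whether the same exchange would stay within the scatter alongside the ethyl group of compound 1 or the amino group of compound 3, since a single pair with the propyl group cannot settle that. Also open, as far as these compounds go, is what a hydrogen, a dimethylamino group or a carboxylic acid would give at this position, and whether compound 2 and compound 4 would remain within the scatter of each other at other doses, as the read-out here comes from one dose and is not a potency.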